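The compounds below may be only part of what the source reports. "The series", "measured", "known", "first", "only" and "open" are said of these compounds alone.

Measured so far:
Compound 1 `COC(=O)C1(S(=O)(=O)c2ccc(Oc3ccc(OC(F)(F)F)cc3)cc2)CCC2(CCNCC2)C1` gives > 15000 nM in this assay, a limit.
Compound 2 `O=S(=O)(c1ccc(Oc2ccc(OC(F)(F)F)cc2)cc1)C1(CO)CCC2(CCNCC2)C1` gives > 15000 nM, also a limit.

In a functional assay on blood (Homo sapiens), with a stated time of 60 min, in the presence of a further agent that is not named here (on this read-out lower numbers stand for an effect already at smaller amounts and higher numbers for an effect only at larger amounts of compound), compound 2 stands only at a limit, > 15000 nM. Compound 1 also sits at a limit, > 15000 nM. Among the measured compounds shown here, the only measured step, a step that the two limits leave unreadable from compound 1 to compound 2, cannot be read because the limit of > 15000 nM in this assay, at which 2 of the 2 values shown sit, holds both values. Compound 3 `CN(C)S(=O)(=O)NC(=O)C1(S(=O)(=O)c2ccc(Oc3ccc(OC(F)(F)F)cc3)cc2)CCC2(CCNCC2)C1` differs from compound 2 in one place: (dimethylsulfamoyl)carbamoyl in place of hydroxymethyl on a saturated ring carbon. No readable step bears on this change, so no direction can be expected beyond the scatter. Compound 3 is therefore estimated at 15000 nM, within 3000 nM to 50000 nM. The step this estimate means, a number no higher from compound 2 to compound 3 (the limit leaves the size open), is expected to stay unreadable.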

Compound 3, half-maximal effective concentration: > 15000 nM
Compound 3 ended at the assay's limit; the forecaster's own chance of this, stated with the estimate: 70%; the middle value lies on the limit itself.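

No step between compound 1, compound 2 and compound 3 can be read, because all three values stop at the same limit: the limit of > 15000 nM in this assay, at which 3 of the 3 values shown sit.

The compounds shown leave open whether hydroxymethyl, methoxycarbonyl and (dimethylsulfamoyl)carbamoyl differ at all in their effect.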